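Swapping Fluoro for Trifluoromethoxy on the Compound with the Lower Number

The source may hold more compounds than are shown below. What is called first, only, known or untested is meant among the compounds shown, and "the series" means these compounds.

Compound 2 `CN1CCN(c2ccc(C3=NN(S(=O)(=O)c4ccc(F)cc4)C(c4ccc(N(C)C)cc4)C3)cc2)CC1` stands lowest of the two measured compounds: in a functional assay on MDA-MB-231 cells (Homo sapiens) for inhibition, read by sulforhodamine B assay, tested at 10 uM (a lower number here means less inhibition, a higher number more inhibition at the concentration tested (going by the name of the read-out)), compound 2 gives 15.7%, whereas compound 1 `CN1CCN(c2ccc(C3=NN(C(=O)c4ccc(C(F)(F)F)cc4)C(c4ccc(N(C)C)cc4)C3)cc2)CC1` gives 55.4%. Among the compounds with values here, the single measured step, a number 39.7 percentage points lower from compound 1 to compound 2 (beyond the scatter), concerns a different part of the molecule, so no measured step bears on the change now considered. Compound 3 `CN1CCN(c2ccc(C3=NN(S(=O)(=O)c4ccc(OC(F)(F)F)cc4)C(c4ccc(N(C)C)cc4)C3)cc2)CC1` differs from compound 2 by trifluoromethoxy in place of fluoro on an aromatic carbon. With nothing to guide it, a step that stays within the usual scatter is expected: a number 6.3 percentage points higher from compound 2 to compound 3 (within the scatter). Compound 3 is therefore estimated at 22%, with a range from 8% to 40%.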

Compound 3, a percentage reported as inhibition, at one concentration (the size of the read-out at that concentration, not a potency): 10.6%
Beside the measured number, compound 3's estimate is 11.4 percentage points above it; the range from low to high includes it.
By their numbers in this assay, from the lowest: compounds 3 and 2 (each within the scatter of the next); then compound 1.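

Putting trifluoromethoxy in place of fluoro on this aromatic carbon gives, in this assay, a number 5.1 percentage points lower from compound 2 to compound 3 (within the scatter). At this position, then, the two groups cannot be told apart in this read-out, even though trifluoromethoxy brings more heavy atoms and a hydrogen-bond acceptor. No measurement at hand explains why they read alike.

Still open, as far as these compounds go, is whether an amine or a carboxylic acid on this carbon would move the number beyond the scatter. Also open, from the compounds shown here alone, is whether a longer chain, such as butoxy, would do so.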